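The source may hold more compounds than are shown below. What is called first, only, known or untested is meant among the compounds shown, and "the series" means these compounds.

Compound 1 `COC(=O)c1ccsc1NC(=O)CSc1snnc1-c1ccc(Br)cc1Br` in an ADME assay on MT4 cells (Homo sapiens) for cytotoxicity, read by MTT assay, with a stated time of 5 days (on this read-out lower numbers stand for higher toxicity in this test and higher numbers for lower toxicity in this test), gives > 227000 nM, which is a limit of the assay and not a number. Compound 2 `O=C(CSc1snnc1-c1ccc(Br)cc1Br)Nc1ccccc1Br` in this assay gives > 221000 nM, again a limit. Compound 3 `O=C(CSc1snnc1-c1ccc(Br)cc1Br)Nc1nccs1` in this assay gives 87800 nM.

Compound 3 therefore stands as the only one of the three with a number; the other two sit at limits. Compound 4 `Cc1ccccc1NC(=O)CSc1snnc1-c1ccc(Br)cc1Br` differs from compound 3 in one place: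
2-methylphenyl in place of 1,3-thiazol-2-yl on an amide-type nitrogen
The step that bears on this runs the opposite way: an at least 2.5-fold lower number from compound 2 to compound 3 (0.40 log units; beyond the scatter). The steps a step that the two limits leave unreadable from compound 1 to compound 2 and an at least 2.5-fold lower number from compound 1 to compound 3 (0.41 log units; beyond the scatter) add little to that picture. Putting an aromatic carbocycle back in place of the thiazolyl is expected to undo the change seen there, so compound 4 is expected to show a higher number, a 2.3-fold higher number from compound 3 to compound 4 (0.36 log units; beyond the scatter), quite possibly reaching the limit again. Compound 4 is thus estimated at 200000 nM, within 90000 nM to 300000 nM.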

Compound 4, half-maximal cytotoxic concentration: 202000 nM
Compound 4: middle estimate off by 1.0-fold (0.00 log units), on the low side; low and high end bracket the measured number.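

In this assay, the lower number of the thiazolyl amide is reversed by a carbocycle that carries no bromo group: a 2.3-fold higher number from compound 3 to compound 4 (0.36 log units; beyond the scatter). Methyl in place of bromo gives an at least 1.0-fold lower number from compound 2 to compound 4 (0.03 log units; that floor lies within the scatter), and the change from the substituted thiophenyl gives an at least 1.1-fold lower number from compound 1 to compound 4 (0.05 log units; that floor lies within the scatter), so neither step shows a real separation among these aryl amides. The value of compound 2 is a limit of the assay and not a number: the limit of > 221000 nM in this assay, at which 1 of the 4 values shown sits.

As far as these compounds go, it remains open whether a pyridinyl ring on this nitrogen would behave like the thiazolyl or like the carbocycles. From the compounds shown here alone, the effect of an amine or a carboxylic acid on the phenyl ring also remains open.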